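Swapping an anilino group for dipropylamino on the shared core

A few compounds are considered here, and "the series" means these few. Any claim that something is new, unique, unknown or untested is made for them only; others in the source may bear on it.

The shared core is that of compound 1 `COc1ccccc1NC1=CC(=O)c2c(nc3n2[C@H]2OC[C@@H](O)[C@H]2OC3)C1=O`, which in a functional assay on MCF7 cells (Homo sapiens) for inhibition, read by sulforhodamine B assay (a higher number here means a weaker inhibitor, a lower number a stronger inhibitor), gives 6580 nM. Compound 2 `O=C1C(Nc2ccccc2)=CC(=O)c2c1nc1n2[C@H]2OC[C@@H](O)[C@H]2OC1` carries hydrogen in place of methoxy on an aromatic carbon. In this assay compound 2 reaches only the limit > 4000 nM. Compound 3 `O=C1C(Nc2ccccc2F)=CC(=O)c2c1nc1n2[C@H]2OC[C@@H](O)[C@H]2OC1` carries fluoro in place of hydrogen on that aromatic carbon. In this assay compound 3 likewise stands at the limit > 4000 nM. The steps a step that the limit leaves unreadable from compound 1 to compound 2, a step that the limit leaves unreadable from compound 1 to compound 3 and a step that the two limits leave unreadable from compound 2 to compound 3 cannot be sized owing to the limit of > 4000 nM in this assay, at which 2 of the 3 values shown sit. Compound 3 thus stands at the limit, with no readable step to any neighbour.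

Compound 4 `CCCN(CCC)C1=CC(=O)c2c(nc3n2[C@H]2OC[C@@H](O)[C@H]2OC3)C1=O` departs from compound 3 in a different way: dipropylamino in place of (2-fluorophenyl)amino on a double-bonded ring carbon. Within the data shown here, none of the three measured steps touches this change; each of them concerns only a substituent on the aromatic ring, so no measured step bears on it, and the three values leave the whole set weak. Compound 4 is therefore expected to remain weak, with a step that the limit leaves unreadable from compound 3 to compound 4 that is not expected to exceed the scatter. For compound 4 the estimate in this assay is 8000 nM, within a range from 3000 nM to 25000 nM.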

Compound 4, half-maximal inhibitory concentration: > 16000 nM
Compound 4: no number, only a limit; the forecaster's own chance of this, stated with the estimate: 60%; middle value at least 2.0-fold (0.30 log units) from the limit.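

In this assay compound 4 gives > 16000 nM, which is a limit of the assay and not a number. With dipropylamino in place of (2-methoxyphenyl)amino on this double-bonded ring carbon, the set gains its first readable step, an at least 2.4-fold higher number from compound 1 to compound 4 (0.38 log units; beyond the scatter), which shows that this open-chain amine brings no gain here over the aromatic amine of compound 1 and leaves a weaker inhibitor. The steps to compound 4 from compound 2 and from compound 3 cannot be read, since each joins two limits: the limit of > 4000 nM in this assay, at which 2 of the 4 values shown sit.

Going by these compounds, what remains open is whether any group on this carbon can bring the shared core into a measurable range of strong inhibition. A shorter amine such as dimethylamino, a cyclic amine such as morpholine or a benzylamino group could test this, and none of the compounds shown bears on it.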